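Swapping the Amide Ring of a Weak Growth Inhibitor

The source may report more compounds than this note shows. Statements on the series, on what has been measured and on what is new or still open speak of the compounds shown alone.

The compounds described here share one core, an unsaturated amide joined to a pyridine-like ring that carries a fused bicyclic ring system. Compound 1 `COC1CN(C(=O)/C=C/c2ccncc2-c2ccc3ccccc3c2)C1` was tested in a functional assay on KB cells (Homo sapiens) for inhibition, read by sulforhodamine B assay, with a stated time of 72 h; a lower number here means a stronger inhibitor of growth, a higher number a weaker inhibitor of growth. In this assay compound 1 reaches only the limit > 10000 nM, so no number is known for it; it sits at the limit of > 10000 nM in this assay, at which 1 of the 3 values shown sits. Two relatives do give numbers. Compound 2 `CNC(=O)/C=C/c1ccncc1-c1ccc2c(ccn2C)c1` gives 7080 nM in this assay. Compound 3 `CCOC(=O)/C=C/c1ccncc1-c1ccc2cc[nH]c2c1` gives 7860 nM in this assay. Both therefore lie close to the top of what the assay can report, and compound 1 stands at or beyond that edge.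

Compound 4 `O=C(/C=C/c1ccncc1-c1ccc2ccccc2c1)N1CCOCC1` has not yet been measured. It differs from compound 1 in one place: morpholin-4-yl in place of 3-methoxyazetidin-1-yl on a carbonyl carbon. Going by the values given here, no pair of measured compounds differs in a single place, so there is no measured step to lean on. Given that all three measured compounds sit near the reporting edge, the step from compound 1 to compound 4 is expected to be small, with no change beyond the scatter: a step that the limit leaves unreadable from compound 1 to compound 4. Compound 4 is therefore estimated at 12000 nM, within a range from 5000 nM to 30000 nM, with a fair chance that only a limit is reported again.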

Compound 4, concentration for 50% growth inhibition: > 10000 nM
Compound 4: a limit, no number; the forecaster's own chance of this, stated with the estimate: 55%; the middle value is on the limit's open side.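

Compound 1 and compound 4 each reach only a limit in this assay and give no number, so no step between them can be read: the limit of > 10000 nM in this assay, at which 2 of the 4 values shown sit.

The compounds shown leave open how far apart compound 1 and compound 4 truly lie, and whether swapping the group on the carbonyl carbon changes growth inhibition at all.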